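Moving the methyl on the terminal phenoxy ring

This account rests on a few compounds, and the source may have more. Where it says the series, first, only, none or still open, it means among the compounds named here.

Compound 2 `Cc1ccccc1Oc1cccc(COc2ccccc2CCC(=O)OCCCOP(=O)(O)OC[C@H](N)C(=O)O)c1` gives 22% in an assay on HEK293 cells for agonist activity at probable G-protein coupled receptor 34 (Homo sapiens), with a stated time of 1 h; on this read-out higher numbers stand for larger maximal responses and lower numbers for smaller maximal responses. Compound 1 `N[C@@H](COP(=O)(O)OCCCOC(=O)CCc1ccccc1OCc1cccc(Oc2ccccc2)c1)C(=O)O` gives 21.7% in this assay, so the two sit within the scatter of each other. Going by the values given here, the only step in hand, a number 0.3 percentage points higher from compound 1 to compound 2 (within the scatter), put a methyl in place of hydrogen on an aromatic carbon. Compound 3 `Cc1cccc(Oc2cccc(COc3ccccc3CCC(=O)OCCCOP(=O)(O)OC[C@H](N)C(=O)O)c2)c1` differs from compound 2 by 3-methylphenyl in place of 2-methylphenyl on an oxygen on an aromatic ring. Because a number 0.3 percentage points higher from compound 1 to compound 2 (within the scatter) stayed within the scatter, this shift of the methyl is expected to bring no step beyond the scatter either, no change at the digits printed from compound 2 to compound 3 (within the scatter). Compound 3 is estimated at 22% in this assay, range 10% to 35%.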

Compound 3, largest response reached (Emax), in percent of the reference or control that the assay uses: 24.2%
Estimate against measurement, compound 3: 2.2 percentage points below; the range from low to high includes it.
By their numbers in this assay, from the lowest: compounds 1, 2 and 3 (each within the scatter of the next).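

In this assay the swap of 2-methylphenyl for 3-methylphenyl on an oxygen on an aromatic ring gives a number 2.2 percentage points higher from compound 2 to compound 3 (within the scatter) so moving the methyl on this ring shows no step beyond the scatter. Set against the unsubstituted phenyl ring, the 3-methylphenyl group gives a number 2.5 percentage points higher from compound 1 to compound 3 (within the scatter) so neither methyl placement shown separates from hydrogen. No measurement at hand bears on the reason for this.

Open, on these data alone, is whether a methoxy group, a chlorine or an amine on this ring would give a step beyond the scatter. As far as these compounds go, a longer chain in place of the methyl also remains open.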